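Adding a chloro group to a cytotoxicity-tested uracil ether

The compounds below may be only part of what the source reports. "The series", "measured", "known", "first", "only" and "open" are said of these compounds alone.

Measured so far in an ADME assay on MT2 cells (Homo sapiens) for cytotoxicity, read by MTT assay; a higher number here means that more compound is tolerated, a lower number that less compound is tolerated:
- compound 1, `N#Cc1cc2c(Oc3ccc(F)cc3OCCn3ccc(=O)[nH]c3=O)cccn2c1`: 100000 nM
- compound 2, `O=c1ccn(CCOc2ccccc2Oc2cccc3cc(Cl)ccc23)c(=O)[nH]1`: a limit, > 100000 nM
- compound 3, `N#C/C=C/c1cc(Cl)cc(Oc2ccccc2OCCn2ccc(=O)[nH]c2=O)c1`: 18000 nM.

The assay gives compound 2 only a limit rather than a number, (the limit of > 100000 nM in this assay, at which 1 of the 3 values shown sits). Among the two numbers that exist, compound 3 stands lowest, so it is the compound that cells tolerate least here; compound 1 gives the higher number, and the gap between compound 1 and compound 3 lies beyond the scatter of this assay.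

Compound 4, `N#C/C=C/c1cc(Cl)cc(Oc2ccc(Cl)cc2OCCn2ccc(=O)[nH]c2=O)c1`, has not yet been measured. It differs from compound 3 in one place: chloro in place of hydrogen on an aromatic carbon. Going by the values given here, no measured pair in this set shows what such a change does to this assay, so there is no direct guide to its size.

The step is expected to be small, perhaps a somewhat lower number for compound 4, but one that could as well sit within the scatter. Compound 4 is therefore estimated at 12000 nM, with a range from 5000 nM to 30000 nM, which means an expected step of a 1.5-fold lower number from compound 3 to compound 4 (0.18 log units; within the scatter).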

Compound 4, half-maximal cytotoxic concentration: 10000 nM
Beside the measured number, compound 4's estimate is 1.2-fold (0.08 log units) above it; low and high end bracket the measured number.
By their numbers in this assay, from the lowest: compounds 4 and 3 (each within the scatter of the next); then compound 1.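

Going by these compounds alone, this is the first measured pair in the set that differs in one place, so it gives the first direct reading of a change on this ring. In this assay, chloro in place of hydrogen on an aromatic carbon, at the place meta to a large group and para to a large group, gives a 1.8-fold lower number from compound 3 to compound 4 (0.26 log units; within the scatter), so this one pair gives no sign that the added chlorine changes how well the cells tolerate the compound. No measurement shown here offers an explanation for this small step.

The compounds shown leave open whether an amine, a carboxylic acid or a methoxy group at this same place would move the number beyond the scatter. They also leave open whether chloro in place of hydrogen would give a similar step on a different core.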